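Pyridin-3-yl in place of phenyl on a sulfonyl sulfur

The source may report more compounds than this note shows. Statements on the series, on what has been measured and on what is new or still open speak of the compounds shown alone.

In a functional assay on HCT-116 cells (Homo sapiens) for inhibition, read by MTT assay, with a stated time of 72 h (on this read-out higher numbers stand for weaker inhibition and lower numbers for stronger inhibition), compound 1 `O=C1C=CC(O)(c2cc3ccccc3n2S(=O)(=O)c2ccccc2)C=C1` gives 30 nM and stands level with the two other measured compounds: compound 2 `CCOC(=O)Nc1ccc(S(=O)(=O)n2c(C3(O)C=CC(=O)C=C3)cc3ccccc32)cc1` gives 30 nM and compound 3 `O=C1C=CC(O)(c2cc3ccccc3n2S(=O)(=O)c2ccc(CCC(=O)O)cc2)C=C1` gives 30 nM at the digits shown. Compound 4 `O=C1C=CC(O)(c2cc3ccccc3n2S(=O)(=O)c2cccnc2)C=C1` is not yet measured and differs from compound 1 by carrying pyridin-3-yl in place of phenyl on a sulfonyl sulfur. Two measured steps alter that phenyl on an aromatic carbon (no change at the digits printed from compound 1 to compound 2 (within the scatter) and no change at the digits printed from compound 1 to compound 3 (within the scatter)) and both lie within the scatter. Neither puts a nitrogen into the ring, so they guide the expectation only loosely. In this assay no step beyond the scatter is therefore expected, and the estimated change (a 1.2-fold higher number from compound 1 to compound 4 (0.07 log units; within the scatter)) is small. Compound 4 is expected at 35 nM within a range of 15 nM to 90 nM in this estimate.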

Compound 4, half-maximal inhibitory concentration: 30 nM
Compound 4: the middle estimate sits 1.2-fold (0.07 log units) above what was measured; the measured number falls inside the stated range.
By their numbers in this assay, from the lowest: compounds 1, 2, 3 and 4 (each within the scatter of the next).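

Putting pyridin-3-yl in place of phenyl on the sulfonyl sulfur gives no change at the digits printed from compound 1 to compound 4 (within the scatter) in this assay. The earlier steps shown here only added groups to an aromatic carbon of the phenyl, whereas this one changes the ring itself, swapping one ring carbon for nitrogen and adding a hydrogen-bond acceptor by count. Nothing available explains this flat result.

The compounds shown leave open whether pyridin-2-yl, pyridin-4-yl or a non-aromatic ring such as piperidin-1-yl on the sulfonyl sulfur would also stay level. Since all four numbers agree, they do not show what change here would move the read-out.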